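Nitro on the Benzamide Ring: Compound 2 to Compound 3

This account rests on a few compounds, and the source may have more. Where it says the series, first, only, none or still open, it means among the compounds named here.

Compound 1 `CN(c1ccc([N+](=O)[O-])cc1OCCc1ccccc1)S(C)(=O)=O`, an assay on SK-BR-3 cells for inhibition of Aromatase (Homo sapiens); on this read-out higher numbers stand for weaker inhibition and lower numbers for stronger inhibition: 520 nM
Compound 2 `O=C(Nc1ccc([N+](=O)[O-])cc1OCc1ccccc1)c1ccccc1`, this assay: > 25000 nM

In this assay compound 1 gives 520 nM. For compound 2 the reading is only a limit, > 25000 nM, as the limit of > 25000 nM in this assay, at which 1 of the 2 values shown sits, records. Compound 3 `O=C(Nc1ccc([N+](=O)[O-])cc1OCc1ccccc1)c1ccc([N+](=O)[O-])cc1` differs from compound 2 by nitro in place of hydrogen on an aromatic carbon. Within the data shown here, no step between two measured compounds is available, so the change is judged from the limit of compound 2 alone, and a shift beyond the usual scatter in either direction cannot be claimed. Compound 3 is expected to land near 30000 nM, within 8000 nM to 100000 nM, most likely again as a limit. That estimate means a step that the limit leaves unreadable from compound 2 to compound 3, no more than scatter.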

Compound 3, half-maximal inhibitory concentration: > 25000 nM
Compound 3: a limit, no number (the forecaster's own chance of this, stated with the estimate: 75%); the middle value is on the limit's open side.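

Among these compounds, compound 2 and compound 3 both read only as limits in this assay, so no step between them can be read. As far as these compounds go, whether going from phenyl to 4-nitrophenyl changes inhibition at all remains open.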